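This account rests on a few compounds, and the source may have more. Where it says the series, first, only, none or still open, it means among the compounds named here.

Compound 2 `Cc1cccnc1-c1cnc(C(=O)CCCCCCc2ccccc2)o1` is one of two compounds with a result in an assay (Rattus norvegicus) for inhibition of Fatty-acid amide hydrolase 1 (Homo sapiens); on this read-out higher numbers stand for weaker inhibition and lower numbers for stronger inhibition. In this assay compound 2 gives 15 nM. The other compound, compound 1 `O=C(CCCCCCc1ccccc1)c1ncc(-c2cccc(C(=O)C(F)(F)F)c2)o1`, gives 16 nM in this assay, a result that lies within the scatter of what compound 2 shows, so the two cannot be told apart on these numbers. Among the compounds with values here, no step between compounds that differ in one place is available, and nothing beyond these two results is known.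

Compound 3 `O=C(CCCCCCc1ccccc1)c1ncc(-c2cc(=O)[nH]c(=O)[nH]2)o1` shares the chain and the five-membered core of compound 2 but carries a different group on the aromatic carbon of that core:

a group of 8 heavy atoms (4 carbon, 2 nitrogen, 2 oxygen; one six-membered aromatic ring with 2 hetero atoms) in place of a group of 7 heavy atoms (6 carbon, 1 nitrogen; one six-membered aromatic ring with 1 hetero atom), on an aromatic carbon

How much such an exchange moves the inhibition constant has not been measured for any pair here, so the direction of the step is uncertain. The writer expects compound 3 to show a somewhat weaker result than compound 2, as a step of a 4.0-fold higher number from compound 2 to compound 3 (0.60 log units; beyond the scatter) in this assay, with the range wide enough to include no change beyond the scatter. The estimate for compound 3 in this assay is 60 nM, between 10 nM and 400 nM.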

Compound 3, inhibition constant: 12 nM
The estimate for compound 3 lay 5.0-fold (0.70 log units) above the measured number; the range from low to high includes it.
By their numbers in this assay, from the lowest: compounds 3, 2 and 1 (each within the scatter of the next).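

In this assay, putting the six-membered ring with two hetero atoms and two double bonds outside the aromatic rings in place of the 3-methylpyridin-2-yl group gives a 1.3-fold lower number from compound 2 to compound 3 (0.10 log units; within the scatter), so the read-out does not separate these two compounds. This is the first one-place exchange shown at this aromatic carbon, next to the ring oxygen of the five-membered aromatic ring, and it shows that two quite different groups there can give results within the scatter of each other, even though the entering group carries hydrogen-bond donors and the leaving group has none. No measurement is available that explains this outcome.

Within the data shown here, with only this one exchange at the position, it remains open whether the inhibition constant would stay within the scatter with a plain phenyl, a pyridin-2-yl lacking the methyl, or a group holding a carboxylic acid or an amine on the same carbon. On these data alone, it is equally open whether the same exchange would behave alike with a shorter chain in place of the one that ends in phenyl.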